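Dropping a terminal hydroxy from a long chain

A few compounds are considered here, and "the series" means these few. Any claim that something is new, unique, unknown or untested is made for them only; others in the source may bear on it.

Within the data shown here, compound 2 `Cc1c(N(C)C)nc(CCCCCCCCCCO)c(O)c1C` stands lowest of the two numbers known so far: in a functional assay on cells (Lymphocyte), read by a luciferase reporter and ATP content, with a stated time of 48 h, tested at 5 uM (a lower number here means a stronger effect, a higher number a weaker effect of the compound at the concentration tested), compound 2 gives 50%, while compound 1 `CCCCCCCCCCc1c(C)c(N(C)C)nc(C)c1O` gives 87%, a gap beyond the usual scatter. Compound 3 `CCCCCCCCCCc1nc(N(C)C)c(C)c(C)c1O` has not been measured yet; it differs from compound 2 by hydrogen in place of hydroxy on a saturated chain carbon, ten or more bonds along the chain from an aromatic carbon. Among the measured compounds shown here, with no measured pair showing this exact change, the step is expected to lean toward a weaker effect, since compound 1, which also carries a plain decyl chain, gives 87%. The step from compound 2 to compound 3 is therefore estimated at a number 25 percentage points higher from compound 2 to compound 3 (beyond the scatter). Compound 3 is expected to give about 75%, with a range from 55% to 95%.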

Compound 3, a percentage reported as activity, at one concentration (the size of the read-out at that concentration, not a potency): 89%
For compound 3 the middle estimate is 14 percentage points below the measured one; measured number inside the range.
By their numbers in this assay, from the lowest: compound 2; then compounds 1 and 3 (each within the scatter of the next).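

Hydrogen in place of hydroxy on a saturated chain carbon gives a number 39 percentage points higher from compound 2 to compound 3 (beyond the scatter) in this assay. This single change is a large step toward a weaker effect, so the chain is not indifferent to what it carries this far along. Nothing measured here explains why the hydroxy matters.

Going by these compounds, whether an amine or a carboxylic acid in its place would match the hydroxy stays open. So does the effect of a longer chain carrying the hydroxy.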